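This account rests on a few compounds, and the source may have more. Where it says the series, first, only, none or still open, it means among the compounds named here.

Compound 1 `O=C(N/N=C/c1ccc(Cl)c(Cl)c1)Nc1ccc(Oc2ccnc3[nH]ccc23)c(F)c1`: 14100 nM
Compound 2 `O=C(N/N=C/c1ccc(F)cc1Cl)Nc1ccc(Oc2ccnc3[nH]ccc23)c(F)c1`: 3 nM
Compound 3 `O=C(N/N=C/c1ccc(O)cc1O)Nc1ccc(Oc2ccnc3[nH]ccc23)c(F)c1`: 13000 nM

In a functional assay on PC-3 cells (Homo sapiens) for antiproliferative activity, read by MTT assay, with a stated time of 72 h (on this read-out higher numbers stand for weaker inhibition and lower numbers for stronger inhibition), compound 3 gives 13000 nM, the second highest of the three numbers. The gap in a 1.1-fold lower number from compound 1 to compound 3 (0.04 log units; within the scatter) lies within the scatter, whereas a 4300-fold higher number from compound 2 to compound 3 (3.64 log units; beyond the scatter) is large. Compound 4 `CN(C)CCn1cccc1/C=N/NC(=O)Nc1ccc(Oc2ccnc3[nH]ccc23)c(F)c1` has 1-(2-(dimethylamino)ethyl)-1H-pyrrol-2-yl in place of 2,4-dihydroxyphenyl on a carbon with a double bond to nitrogen. All measured steps are at this same place, and a 4700-fold lower number from compound 1 to compound 2 (3.67 log units; beyond the scatter) is also large, so changes here have done either almost nothing or a great deal. Within the data shown here, no measured compound has a five-membered aromatic ring here. With compound 3 near the top of the measured numbers and compound 2 at 3 nM, a lower number is more likely than a higher one. The expected step is a 13-fold lower number from compound 3 to compound 4 (1.11 log units; beyond the scatter), large but poorly fixed. Compound 4 is estimated at 1000 nM, with an expected range from 30 nM to 20000 nM.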

Compound 4, half-maximal inhibitory concentration: 1600 nM
Estimate against measurement, compound 4: 1.6-fold (0.20 log units) below; the measured number falls inside the stated range.
By their numbers in this assay, from the lowest: compound 2; then compound 4; then compounds 3 and 1 (each within the scatter of the next).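

In this assay the steps of an 8.1-fold lower number from compound 3 to compound 4 (0.91 log units; beyond the scatter) and an 8.8-fold lower number from compound 1 to compound 4 (0.95 log units; beyond the scatter) are modest, while a 530-fold higher number from compound 2 to compound 4 (2.73 log units; beyond the scatter) is large, so this position now shows an intermediate result as well as near-silent and very large changes. A five-membered aromatic ring with a 2-(dimethylamino)ethyl chain therefore improves on the 2,4-dihydroxyphenyl and 3,4-dichlorophenyl groups but stays far from 2-chloro-4-fluorophenyl. No measured evidence accounts for these steps.

The shift cannot yet be assigned to the pyrrole ring or to its chain. A plain 1H-pyrrol-2-yl group and a phenyl ring carrying the 2-(dimethylamino)ethyl chain would separate the two.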